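A Second Cyano Group on Compound 3

A few compounds are considered here, and "the series" means these few. Any claim that something is new, unique, unknown or untested is made for them only; others in the source may bear on it.

In a functional assay on Jurkat cells (Homo sapiens) for cytotoxicity, read by luminescence and CellTiter-Glo, with a stated time of 3 days (a higher number here means a weaker inhibitor, a lower number a stronger inhibitor), compound 1 `N#Cc1cc(Cl)ccc1NC(=O)c1ccc2cccnc2c1O` gives 170 nM and compound 2 `N#Cc1ccc(NC(=O)c2ccc3cccnc3c2O)c(F)c1` gives 420 nM while compound 3 `N#Cc1ccc(NC(=O)c2ccc3cccnc3c2O)cc1` gives 180 nM as the second highest of the three numbers. Compound 3 thus lies within the scatter of compound 1 and clearly apart from compound 2. Compound 4 `N#Cc1ccc(NC(=O)c2ccc3cccnc3c2O)c(C#N)c1` has not yet been measured. The change cyano in place of hydrogen on an aromatic carbon puts cyano in place of hydrogen on an aromatic carbon, ortho to a large group and meta to a cyano group.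

The closest evidence comes from that same place on the ring. There, hydrogen in place of fluoro gave a 2.3-fold lower number from compound 2 to compound 3 (0.37 log units; beyond the scatter) as a modest step beyond the scatter. Read in reverse, it links a group at this place with a higher number. Compound 1 goes against that reading, since it also carries cyano ortho to a large group, yet its 170 nM lies within the scatter of compound 3. A small shift towards a higher number is therefore expected, not clearly beyond the scatter. The expected step is a 1.7-fold higher number from compound 3 to compound 4 (0.22 log units; within the scatter) in this assay on this limited evidence. Compound 4 is estimated at 300 nM with an expected range from 120 nM to 700 nM around that value.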

Compound 4, half-maximal inhibitory concentration: 270 nM
Estimate against measurement, compound 4: 1.1-fold (0.05 log units) above, within the range that was stated.
By their numbers in this assay, from the lowest: compounds 1, 3, 4 and 2 (each within the scatter of the next, the first and the last beyond it).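

In this assay, cyano in place of hydrogen on an aromatic carbon, ortho to a large group and meta to a cyano group, gives a 1.5-fold higher number from compound 3 to compound 4 (0.18 log units; within the scatter), so a group larger than fluoro is accepted at this place without a step that stands clear of the scatter. Cyano in place of fluoro at the same place gives a 1.6-fold lower number from compound 2 to compound 4 (0.19 log units; within the scatter), which leaves compound 4 within the scatter of both compound 2 and compound 3, even though those two stand apart by a 2.3-fold lower number from compound 2 to compound 3 (0.37 log units; beyond the scatter); the earlier reading, that a group at this place goes with a higher number, therefore rests on compound 2 alone and gains no firm support from compound 4. Cyano in place of chloro, a change at another place on the ring, gives a 1.6-fold higher number from compound 1 to compound 4 (0.20 log units; within the scatter), so that place also shows no step beyond the scatter for this pair of groups.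

Going by these compounds, whether an amine or a carboxylic acid at the place of the new cyano group would move the number beyond the scatter, in either direction, stays open. Nothing shown here bears on why these numbers fall as they do.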